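This account rests on a few compounds, and the source may have more. Where it says the series, first, only, none or still open, it means among the compounds named here.

Measured compounds:
compound 1 `O=C(Nc1cccc(-n2cc(-c3ccncc3)c(-c3cc(O)cc(Cl)c3)n2)c1)Nc1ccc(Cl)c(C(F)(F)F)c1`: -13.5%
compound 2 `COc1cc(Cl)cc(-c2nn(-c3cccc(NC(=O)Nc4ccc(Cl)c(C(F)(F)F)c4)c3)cc2-c2ccncc2)c1`: 23.6%
compound 3 `COc1cc(Cl)cc(-c2nn(-c3cccc(NC(=O)Nc4cc(C(F)(F)F)cc(C(F)(F)F)c4)c3)cc2-c2ccncc2)c1`: 6.55%

In a functional assay on SK-MEL-28 cells (Homo sapiens) for inhibition, read by sulforhodamine B assay, with a stated time of 48 h, tested at 10 uM (on this read-out lower numbers stand for a stronger effect and higher numbers for a weaker effect at the one concentration tested), compound 2 gives 23.6%, the highest of the three numbers and hence the weakest effect; compound 3 gives 6.55% and compound 1 gives -13.5%. Compound 4 `COc1cc(Cl)cc(-c2nn(-c3cccc(NC(=O)c4cccc(C(F)(F)F)c4)c3)cc2-c2ccncc2)c1` differs from compound 2 by 3-(trifluoromethyl)phenyl in place of (4-chloro-3-(trifluoromethyl)phenyl)amino on a carbonyl carbon. Within the data shown here, the only measured step, a number 37.1 percentage points higher from compound 1 to compound 2 (beyond the scatter), concerns a methyl in place of hydrogen on an oxygen on an aromatic ring, a different place, so it does not bear on this change, and compound 3 shares the whole of the altered region with neither compound. Compound 4 is therefore expected to show no step beyond the scatter, a number 3.6 percentage points lower from compound 2 to compound 4 (within the scatter). The estimated value of compound 4 is 20%, with a range from -5% to 45%.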

Compound 4, a percentage reported as activity, at one concentration (the size of the read-out at that concentration, not a potency): 70.4%
Compound 4: middle estimate off by 50.4 percentage points, on the low side; measured number outside the range, above it.
By their numbers in this assay, from the lowest: compound 1; then compound 3; then compound 2; then compound 4.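

In this assay, among these compounds, 3-(trifluoromethyl)phenyl in place of (4-chloro-3-(trifluoromethyl)phenyl)amino on the carbonyl carbon gives a number 46.8 percentage points higher from compound 2 to compound 4 (beyond the scatter), so this position, unchanged at its amino link in the earlier compounds, strongly affects the read-out. The change removes the amino nitrogen and the chlorine together, and the step cannot be divided between them. No measurement at hand explains the step.

The compounds shown leave open which of those two losses matters, and how a methylene or methylamino link on the same carbonyl carbon would read.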